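The source may hold more compounds than are shown below. What is called first, only, known or untested is meant among the compounds shown, and "the series" means these compounds.

Measured in a functional assay on MDA-MB-231 cells (Homo sapiens) for antiproliferative activity, read by MTT assay, with a stated time of 24 h; a higher number here means a weaker inhibitor, a lower number a stronger inhibitor:
Compound 1 `Cc1ccccc1NNC(=O)c1cccc(NS(=O)(=O)c2cnc(O)nc2O)c1`: > 20000 nM, a limit.
Compound 2 `Cc1cccc(NNC(=O)c2cccc(NS(=O)(=O)c3cnc(O)nc3O)c2)c1`: > 20000 nM, a limit.
Compound 3 `O=C(NNc1ccc(F)cc1)c1cccc(NS(=O)(=O)c2cnc(O)nc2O)c1`: > 20000 nM, a limit.

Compound 3 has no number, only a limit, and the whole series stands at the limit of > 20000 nM in this assay, at which 3 of the 3 values shown sit. Compound 4 `Cc1ccccc1C(=O)NNC(=O)c1cccc(NS(=O)(=O)c2cnc(O)nc2O)c1` carries (2-methylphenyl)carbonyl in place of 4-fluorophenyl on an amine nitrogen. Cut one bond further out, the change reads (4-fluorophenyl)amino to ((2-methylphenyl)carbonyl)amino. The measured steps that bear on it are the swaps at that same nitrogen: a step that the two limits leave unreadable from compound 1 to compound 2, a step that the two limits leave unreadable from compound 1 to compound 3 and a step that the two limits leave unreadable from compound 2 to compound 3. None of them has a readable size, and none brings in a carbonyl, so they offer no size or direction to carry over. The working expectation in this assay is therefore no step beyond the scatter, with the result most likely reported again as a limit. The expected step is a number no higher from compound 3 to compound 4 (the limit leaves the size open). For compound 4 the estimate is 20000 nM, with an expected range of 6000 nM to 40000 nM.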

Compound 4, half-maximal inhibitory concentration: 18100 nM
The estimate for compound 4 lay 1.1-fold (0.04 log units) above the measured number, within the range that was stated.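

In this assay compound 4 gives 18100 nM, the only reading at this amine nitrogen that is a number and not a limit, and (2-methylphenyl)carbonyl is also the only group shown there that brings in a carbonyl. From the compounds shown here alone, the steps read an at least 1.1-fold lower number from compound 3 to compound 4 (0.04 log units; that floor lies within the scatter), an at least 1.1-fold lower number from compound 2 to compound 4 (0.04 log units; that floor lies within the scatter) and an at least 1.1-fold lower number from compound 1 to compound 4 (0.04 log units; that floor lies within the scatter); each is only a floor, so the swap to this group cannot yet be credited with a real gain, and its true size stays unknown. The other values in the series remain limits: the limit of > 20000 nM in this assay, at which 3 of the 4 values shown sit.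

The steps among compounds 1, 2 and 3 cannot be read. Going by these compounds, it remains open whether the methyl on the new group matters, and how an unsubstituted benzoyl, an acetyl or a longer alkyl chain at this nitrogen would read.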